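Lengthening the Amine Tail on the Shared Core

The source may report more compounds than this note shows. Statements on the series, on what has been measured and on what is new or still open speak of the compounds shown alone.

Three measured compounds share one core and differ only in the group carried by an aromatic nitrogen. Compound 1 `O=C1c2c[n+]([O-])c3ccccc3c2C(=O)c2c1c1ccccc1n2Cc1cn([C@@H]2C[C@H](O)[C@@H](CO)O2)nn1` is the strongest of them in a functional assay on A-375 cells (Homo sapiens) for cytotoxicity, read by MTT assay, with a stated time of 72 h (a higher number here means a weaker inhibitor, a lower number a stronger inhibitor), where compound 1 gives 20 nM. Compound 3 `CC1(C)O[C@@H](CO)[C@H](Cn2cc(Cn3c4c(c5ccccc53)C(=O)c3c[n+]([O-])c5ccccc5c3C4=O)nn2)O1` gives 190 nM in this assay, a change of a 9.5-fold higher number from compound 1 to compound 3 (0.98 log units; beyond the scatter). Compound 2 `O=C1c2c[n+]([O-])c3ccccc3c2C(=O)c2c1c1ccccc1n2CCN1CCCC1` gives 430 nM in this assay, the highest of the three numbers, separated from compound 3 and from compound 1 by gaps beyond the scatter.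

Compound 4 `CN1CCN(CCCCCn2c3c(c4ccccc42)C(=O)c2c[n+]([O-])c4ccccc4c2C3=O)CC1` differs from compound 2 in one place: 3-(4-methylpiperazin-1-yl)propyl in place of pyrrolidin-1-yl on a saturated chain carbon, two bonds along the chain from an aromatic nitrogen. Among the measured compounds shown here, no measured step touches this part of the molecule; the single step available, from compound 1 to compound 3, concerns a different region. With nothing comparable to lean on, the step from compound 2 to compound 4 is expected to stay within the scatter, a 1.4-fold lower number from compound 2 to compound 4 (0.16 log units; within the scatter). Compound 4 is therefore estimated to give 300 nM in this assay, within a wide range from 100 nM to 1200 nM.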

Compound 4, half-maximal inhibitory concentration: 1710 nM
Compound 4: middle estimate off by 5.7-fold (0.76 log units), on the low side; the whole stated range lies below it.
By their numbers in this assay, from the lowest: compound 1; then compound 3; then compound 2; then compound 4.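

In this assay, putting 3-(4-methylpiperazin-1-yl)propyl in place of pyrrolidin-1-yl, on a saturated chain carbon, two bonds along the chain from an aromatic nitrogen, gives a 4.0-fold higher number from compound 2 to compound 4 (0.60 log units; beyond the scatter). Among the compounds shown here, the only earlier step lay in a different region, so this is the first sign that the far end of this tail affects the result, with weaker inhibition here in the compound with the longer chain and the piperazine ring. The chain and the ring change together, and no measurement at hand explains the rise.

The compounds shown therefore cannot say which of the two changes matters. A 5-(pyrrolidin-1-yl)pentyl tail or a 2-(4-methylpiperazin-1-yl)ethyl tail would separate them, while a tail ending in a carboxylic acid remains an open question.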